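This account rests on a few compounds, and the source may have more. Where it says the series, first, only, none or still open, it means among the compounds named here.

Measured so far in an assay on cell membranes for binding affinity to Fatty-acid amide hydrolase 1 (Rattus norvegicus); a lower number here means a stronger inhibitor, a higher number a weaker inhibitor:
compound 1, `Cc1ccc(-c2cccc(OC(=O)NC3CCCCC3)c2)cc1` — 155 nM
compound 2, `O=C(NC1CCCCC1)Oc1cccc(-c2ccc(F)cc2)c1` — 65 nM
compound 3, `O=C(NC1CCCCC1)Oc1cccc(-c2cccc(F)c2)c1` — 96.6 nM

Compound 3 sits second highest of these three numbers; its nearest neighbour is compound 2, its furthest compound 1, and both gaps lie within the scatter, so the three cannot be ranked against each other. The step to compound 4, `O=C(NC1CCCCC1)Oc1cccc(-c2cccc(Oc3ccccc3)c2)c1`, is phenoxy in place of fluoro on an aromatic carbon, placed on an aromatic carbon of a six-membered aromatic ring of carbon only, meta to a large group.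

The measured steps all change a small substituent on the same ring. a 2.4-fold lower number from compound 1 to compound 2 (0.38 log units; beyond the scatter) was modest; a 1.6-fold lower number from compound 1 to compound 3 (0.21 log units; within the scatter) and a 1.5-fold higher number from compound 2 to compound 3 (0.17 log units; within the scatter) stayed within the scatter. None of them exchanges a single atom for a whole phenoxy group, so they say little about a change of this size; what they show is that this ring tolerates small changes without much movement in this assay. The step of a 1.1-fold lower number from compound 3 to compound 4 (0.03 log units; within the scatter) is therefore expected to be small, with wide uncertainty in either direction. Compound 4 is estimated at 90 nM, within a range from 25 nM to 320 nM.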

Compound 4, half-maximal inhibitory concentration: 420 nM
Compound 4: the middle estimate sits 4.7-fold (0.67 log units) below what was measured; measured number above the stated range.
By their numbers in this assay, from the lowest: compounds 2, 3 and 1 (each within the scatter of the next, the first and the last beyond it); then compound 4.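

In this assay, putting a whole phenoxy group where a single fluoro atom stood gives a 4.3-fold higher number from compound 3 to compound 4 (0.64 log units; beyond the scatter), so the weaker number here is a step beyond the scatter. The near-flat picture left by the small substituents on this ring therefore does not carry over to a change of this size, although compound 4 still gives a measured number and this aromatic carbon does accept a group that brings a second aromatic ring and an oxygen. Nothing available here tells which feature of the exchange lies behind this step, and no measurement bears on its cause.

With one large group at this place, size, the added ring and the linking oxygen all enter together and cannot be told apart. A methoxy group, which brings the oxygen without the ring, and a phenyl group, which brings the ring without the oxygen, are not among the compounds shown, so it remains open whether either one alone would move the number, or whether an amine at the same carbon would behave differently.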